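Methylphenyl Sulfonamide Weighed Against Chloro and Methoxy Analogues

This account rests on a few compounds, and the source may have more. Where it says the series, first, only, none or still open, it means among the compounds named here.

Of the compounds shown here, three built on one shared core have been measured in an assay on isolated protein for binding affinity to histamine H2 receptor (Homo sapiens); a lower number here means a stronger inhibitor, a higher number a weaker inhibitor. Compound 1 `O=C(c1ccc(OCCCN2CC[C@H](NS(=O)(=O)c3ccc(Br)cc3)C2)cc1)C1CC1` carries a bromo group on the aromatic ring attached to the sulfonyl sulfur and gives 290 nM. Compound 2 `COc1ccc(S(=O)(=O)N[C@H]2CCN(CCCOc3ccc(C(=O)C4CC4)cc3)C2)cc1` has a methoxy in place of that bromo on an aromatic carbon and gives 1000 nM. Compound 3 `O=C(c1ccc(OCCCN2CC[C@H](NS(=O)(=O)c3ccc(Cl)cc3)C2)cc1)C1CC1` has a chloro in that place and gives 290 nM; it stands level with compound 1, the two sharing the lowest number of the three, while compound 2 sits apart from both.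

The measured steps frame the picture: no change at the digits printed from compound 1 to compound 3 (within the scatter), whereas a 3.4-fold higher number from compound 1 to compound 2 (0.54 log units; beyond the scatter) and, read the other way, a 3.4-fold lower number from compound 2 to compound 3 (0.54 log units; beyond the scatter).

Compound 4 `Cc1ccccc1S(=O)(=O)N[C@H]1CCN(CCCOc2ccc(C(=O)C3CC3)cc2)C1` differs from compound 3 in one place: 2-methylphenyl in place of 4-chlorophenyl on a sulfonyl sulfur. Going by the values given here, no measured compound carries a methyl on this ring, so the known steps only bracket the change. Exchanging one halogen for another left this assay unmoved, and the methoxy cost a modest amount; a small loss seems most likely, with no change beyond the scatter also plausible.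

Compound 4 is therefore expected to give about 500 nM, within a range from 200 nM to 1500 nM. The step this estimate implies, a 1.7-fold higher number from compound 3 to compound 4 (0.24 log units; within the scatter), is expected to be modest at most.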

Compound 4, inhibition constant: 2200 nM
Beside the measured number, compound 4's estimate is 4.4-fold (0.64 log units) below it; measured number above the stated range.
By their numbers in this assay, from the lowest: compounds 1 and 3 (each within the scatter of the next); then compound 2; then compound 4.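

In this assay, the swap on the sulfonyl sulfur produced the largest steps seen so far in this small set: a 7.6-fold higher number from compound 3 to compound 4 (0.88 log units; beyond the scatter), and likewise a 7.6-fold higher number from compound 1 to compound 4 (0.88 log units; beyond the scatter). Compound 2, which held the highest number among the earlier three, does not mark the upper end of what this position can give, as there is also a 2.2-fold higher number from compound 2 to compound 4 (0.34 log units; beyond the scatter), leaving compound 4 with the highest number of the four. Nothing in the data shown accounts for this drop in binding.

Replacing 4-chlorophenyl with 2-methylphenyl changes both the group on the ring and its place on that ring, so these steps cannot separate the two changes. Going by these compounds, a 4-methylphenyl or a 2-chlorophenyl on the sulfonyl sulfur would be needed to tell them apart, and whether either would give a number closer to compound 3 or to compound 4 remains open.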